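This account rests on a few compounds, and the source may have more. Where it says the series, first, only, none or still open, it means among the compounds named here.

Measured so far in an ADME assay on A549 cells (Homo sapiens) for cytotoxicity, read by CellTiter-Glo; on this read-out lower numbers stand for higher toxicity in this test and higher numbers for lower toxicity in this test:
- compound 1 `Cc1c(Cc2ccc(F)cc2)c(=O)oc2cc(OCC(O)CN3CCC(C(N)=O)CC3)ccc12`: 89300 nM
- compound 2 `COc1ccccc1-c1ccc(Cc2c(C)c3ccc(OCC(O)CN4CCC(C(N)=O)CC4)cc3oc2=O)cc1`: 91600 nM

Going by the values given here, compound 2 stands together with compound 1 in this assay; the only measured step, a 1.0-fold higher number from compound 1 to compound 2 (0.01 log units; within the scatter), lies within the scatter, so the two numbers are not separated. Compound 3 `Cc1c(Cc2ccc(-c3ccccc3C#N)cc2)c(=O)oc2cc(OCC(O)CN3CCC(C(N)=O)CC3)ccc12` differs from compound 2 by cyano in place of methoxy on an aromatic carbon. Among the compounds with values here, no measured step covers cyano in place of methoxy, and the single step available is within the scatter, so no change beyond the scatter is expected here. The estimate for compound 3 in this assay is 90000 nM (range 45000 nM to 180000 nM), an expected step of a 1.0-fold lower number from compound 2 to compound 3 (0.01 log units; within the scatter).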

Compound 3, half-maximal cytotoxic concentration: 33200 nM
Compound 3: middle estimate off by 2.7-fold (0.43 log units), on the high side, and the stated range ends above it.
By their numbers in this assay, from the lowest: compound 3; then compounds 1 and 2 (each within the scatter of the next).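

In this assay, going by these compounds alone, cyano in place of methoxy gives a 2.8-fold lower number from compound 2 to compound 3 (0.44 log units; beyond the scatter), the first step beyond the scatter, so this position on the aromatic ring is not indifferent to its substituent. 2-Cyanophenyl in place of fluoro gives a 2.7-fold lower number from compound 1 to compound 3 (0.43 log units; beyond the scatter), whereas 2-methoxyphenyl in place of fluoro left the number within the scatter; the added phenyl ring alone therefore does not set the number, and the group on it matters here.

On these data alone, whether an amine or a carboxylic acid at this place would keep the number low or return it to the level of compound 2 remains open. Nothing available explains the lower number for compound 3.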